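The source may hold more compounds than are shown below. What is called first, only, known or untested is meant among the compounds shown, and "the series" means these compounds.

Compound 1 `CCc1nnc(SCc2ccccc2)n1N1C(=O)c2ccccc2C1=O` in a functional assay on MKN-45 cells (Homo sapiens) for cytotoxicity, read by MTT assay, with a stated time of 48 h (on this read-out higher numbers stand for weaker inhibition and lower numbers for stronger inhibition), gives > 200000 nM, a limit of the assay.
Compound 2 `CCc1nnc(SCC(=O)c2ccccc2)n1N1C(=O)c2ccccc2C1=O` in this assay gives > 200000 nM, also a limit.
Compound 3 `CCc1nnc(SC)n1N1C(=O)c2ccccc2C1=O` in this assay gives > 200000 nM, again a limit.

Compound 3 thus stands at the same limit as the other two, the point described by the limit of > 200000 nM in this assay, at which 3 of the 3 values shown sit, and no numerical order among the three can be drawn. The steps a step that the two limits leave unreadable from compound 1 to compound 2, a step that the two limits leave unreadable from compound 1 to compound 3 and a step that the two limits leave unreadable from compound 2 to compound 3 all concern the group on the sulfur-bound chain carbon and none of them is readable in size.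

Compound 4 `CCCc1nnc(SC)n1N1C(=O)c2ccccc2C1=O` differs from compound 3 by methyl in place of hydrogen on a saturated chain carbon, two bonds along the chain from an aromatic carbon; read one bond further out, the change is ethyl to propyl on the core. Among the compounds with values here, no measured step touches this position, so the only guide is that every variation so far, including compound 3 with > 200000 nM, has remained at the limit. Compound 4 is therefore expected to stay near that limit, with the step that the limit leaves unreadable from compound 3 to compound 4 expected to be none beyond the scatter. The estimate for compound 4 in this assay is 250000 nM, within 100000 nM to 1000000 nM, most likely reported only as a limit.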

Compound 4, half-maximal inhibitory concentration: > 200000 nM
Compound 4 ended at the assay's limit; the forecaster's own chance of this, stated with the estimate: 85%; the middle value is on the limit's open side.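

Compound 3 and compound 4 both sit at a limit in this assay, so the step between them cannot be read: the limit of > 200000 nM in this assay, at which 4 of the 4 values shown sit.

The compounds shown leave open how far any of the four lies past that limit, and whether changing either varied group affects the read-out at all.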